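Moving the chloro group: an expectation for compound 4

The source may report more compounds than this note shows. Statements on the series, on what has been measured and on what is new or still open speak of the compounds shown alone.

Of the compounds shown here, three have so far been measured in a functional assay on the whole organism (strain Wistar) for inhibition, with Rattus norvegicus as the target, read by paw edema, with a stated time of 30 min, at a dose of 10 mg/kg by the intraperitoneal route; a lower number here means less inhibition, a higher number more inhibition at the dose given (going by the name of the read-out). Compound 1 `COc1cc(/C=N/NC(=O)c2cccnc2Nc2cccc(C(F)(F)F)c2)cc(OC)c1OC` gives 55.9%, compound 2 `CNc1ncccc1C(=O)N/N=C/c1ccccc1` gives 56.5%, and compound 3 `CNc1ncccc1C(=O)N/N=C/c1cccc(Cl)c1` gives 67.1%. Compound 2 thus stands second highest of the three: its number and that of compound 1 lie within the scatter of each other, while compound 3 sits beyond the scatter above it. Going by the values given here, the only single-change step among the measured compounds is a number 10.6 percentage points higher from compound 2 to compound 3 (beyond the scatter), a modest rise.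

Compound 4 `CNc1ncccc1C(=O)N/N=C/c1ccc(Cl)cc1` has not yet been measured in this assay. It differs from compound 2 in one place: chloro in place of hydrogen on an aromatic carbon, the incoming chloro sitting para to a large group. The step from compound 2 to compound 3 is the one that bears on this, since there too a chloro replaced hydrogen on the same ring and the number rose modestly. A rise of similar size is therefore expected, and the expected step is a number 8.5 percentage points higher from compound 2 to compound 4 (within the scatter). The estimate for compound 4 in this assay is 65%, with a range from 54% to 76%.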

Compound 4, a percentage reported as inhibition, in the whole organism at one dose (the size of the read-out at that dose, not a potency): 46.5%
The estimate for compound 4 lay 18.5 percentage points above the measured number; measured number outside the range, below it.
By their numbers in this assay, from the lowest: compounds 4, 1 and 2 (each within the scatter of the next); then compound 3.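

In this assay, chloro in place of hydrogen on an aromatic carbon, para to a large group, gives a number 10 percentage points lower from compound 2 to compound 4 (within the scatter), so at this place the change does not repeat a number 10.6 percentage points higher from compound 2 to compound 3 (beyond the scatter). The same group on the same ring thus does not carry one result from place to place: compound 3 gives 67.1% and compound 4 gives 46.5%. No measurement at hand offers a reason for this difference.

As far as these compounds go, whether an amine or a carboxylic acid at this place would read differently from chloro remains open. Also open, from the compounds shown here alone, is how compound 2 and compound 4 would compare at other doses or at other times, since the read-out here reflects a single dose and a single stated time.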